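Tetrazole for Triazole: Expected Change in Cell Viability

The source may report more compounds than this note shows. Statements on the series, on what has been measured and on what is new or still open speak of the compounds shown alone.

Compound 1 `Cc1ccc(-c2cs/c(=N/NC(=O)CSc3nncn3C)n2-c2ccccc2)cc1` gives 74.6% in a functional assay on C6 cells (Rattus norvegicus) for cytotoxicity, read by MTT assay, with a stated time of 24 h, tested at 6 ug/mL; a higher number here means a weaker effect of the compound at the concentration tested, a lower number a stronger effect.
Compound 2 `Cc1ccc(-c2cs/c(=N/NC(=O)CSc3nnnn3C)n2-c2ccccc2)cc1` gives 88% in this assay.
Compound 3 `Cn1cnnc1SCC(=O)N/N=c1/scc(-c2ccc(C#N)cc2)n1-c1ccccc1` gives 70.2% in this assay.

Compound 4 `Cn1nnnc1SCC(=O)N/N=c1/scc(-c2ccc(C#N)cc2)n1-c1ccccc1` has not yet been measured in this assay.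

Compound 1 and compound 2 differ by 1-methyl-1H-tetrazol-5-yl in place of 4-methyl-4H-1,2,4-triazol-3-yl on a sulfur. This change produced a number 13.4 percentage points higher from compound 1 to compound 2 (beyond the scatter). Compound 4 differs from compound 3 by 1-methyl-1H-tetrazol-5-yl in place of 4-methyl-4H-1,2,4-triazol-3-yl on a sulfur, and since the sulfur carrying the ring is described with the same neighbour in both cases, this is the same change at the same kind of place. The two cores differ by cyano in place of methyl on an aromatic carbon, which gave a number 4.4 percentage points lower from compound 1 to compound 3 (within the scatter). Among the three measured compounds, compound 3 has the lowest number, but its gap to compound 1 lies within the scatter, so no order between those two should be read from it; only its gap to compound 2 is beyond the scatter.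

The expectation for compound 4 rests on a single matched pair. Because the change on the methyl core gave a number 13.4 percentage points higher from compound 1 to compound 2 (beyond the scatter), a step of similar size is expected on the cyano core for compound 4, a number 12.8 percentage points higher from compound 3 to compound 4 (beyond the scatter). Going by the values given here, with only one precedent, the range is kept wide. Compound 4 is expected to give about 83%, estimated to lie between 72% and 94%.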

Compound 4, a percentage reported as activity, at one concentration (the size of the read-out at that concentration, not a potency): 63.5%
For compound 4 the middle estimate is 19.5 percentage points above the measured one; measured number outside the range, below it.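

On the cyano core, placing 1-methyl-1H-tetrazol-5-yl in place of 4-methyl-4H-1,2,4-triazol-3-yl on a sulfur gave, in this assay, a number 6.7 percentage points lower from compound 3 to compound 4 (within the scatter), so the step seen on the methyl core did not carry over to this core: the same change on two cores in this assay, a number 13.4 percentage points higher (beyond the scatter) from compound 1 to compound 2 and a number 6.7 percentage points lower (within the scatter) from compound 3 to compound 4, 20.1 percentage points apart, beyond the scatter of two such steps. The reverse reading holds for the other change, since cyano in place of methyl on an aromatic carbon gave a number 24.5 percentage points lower from compound 2 to compound 4 (beyond the scatter) with 1-methyl-1H-tetrazol-5-yl on the sulfur, and the effect of each change therefore depended on the group present at the other place: the same change on two cores in this assay, a number 4.4 percentage points lower (within the scatter) from compound 1 to compound 3 and a number 24.5 percentage points lower (beyond the scatter) from compound 2 to compound 4, 20.1 percentage points apart, beyond the scatter of two such steps. Going by these compounds alone, this shows that, across these two cores, the step from one change could not be transferred to the other core, but with only one pair on each core it does not establish a rule for the series or give the cyano core a step beyond the scatter.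

Going by these compounds, it remains open whether another group on that aromatic carbon, such as chlorine or methoxy, would behave like methyl or like cyano when the two rings on the sulfur are exchanged. Also open, on these data alone, is whether the same dependence would appear with an ethyl group in place of the methyl on either ring.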